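The compounds below may be only part of what the source reports. "The series", "measured", "known", "first", "only" and "open" are said of these compounds alone.

Compound 3 `Brc1ccc(C2=NN(c3nc(-c4ccc(Br)cc4)cs3)C(c3cccs3)C2)cc1` gives the highest number of the three measured in a functional assay on WM 266-4 cells (Homo sapiens) for antiproliferative activity, read by MTT assay, with a stated time of 48 h (on this read-out lower numbers stand for stronger inhibition and higher numbers for weaker inhibition), at 13000 nM. Its nearest neighbour is compound 2 `Cc1ccc(C2=NN(c3nc(-c4ccccc4)cs3)C(c3cccs3)C2)cc1`, which in this assay gives 7520 nM, a value within the scatter of that of compound 3. Furthest away is compound 1 `Fc1ccc(C2=NN(c3nc(-c4ccccc4)cs3)C(c3cccs3)C2)cc1`, which in this assay gives 170 nM, far beyond the scatter from compound 3.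

Compound 4 `Brc1ccc(C2=NN(c3nc(-c4ccccc4)cs3)C(c3cccs3)C2)cc1` differs from compound 3 in one place: hydrogen in place of bromo on an aromatic carbon, the same difference cut one bond further out reading 4-bromophenyl to phenyl. Within the data shown here, no measured step touches this position. Among the measured compounds shown here, the only measured step, a 44-fold higher number from compound 1 to compound 2 (1.65 log units; beyond the scatter), concerns a different ring, the one attached to the pyrazoline, and shows how much the number can move when that ring is changed; it says nothing direct about the ring attached to the thiazole. Compound 2 and compound 4 carry the same unsubstituted ring on the thiazole and differ only on the other ring, and the values of compound 2 and compound 3 lie within the scatter of each other. The expected step is therefore small, a 2.6-fold lower number from compound 3 to compound 4 (0.41 log units; beyond the scatter), with no firm direction. Compound 4 is estimated in this assay at 5000 nM, with a range from 1500 nM to 15000 nM.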

Compound 4, half-maximal inhibitory concentration: 1870 nM
Estimate against measurement, compound 4: 2.7-fold (0.43 log units) above; the measured number falls inside the stated range.
By their numbers in this assay, from the lowest: compound 1; then compound 4; then compounds 2 and 3 (each within the scatter of the next).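

In this assay, among these compounds, compound 4 gives the first reading of a change at the position para to a large group on this six-membered aromatic ring: 4-bromophenyl to phenyl gives a 7.0-fold lower number from compound 3 to compound 4 (0.84 log units; beyond the scatter), so this position is not indifferent to the group it carries, at least with bromo on the other ring. Compound 4 also adds bromo to the series on that other ring, with phenyl held constant, giving a 4.0-fold lower number from compound 2 to compound 4 (0.60 log units; beyond the scatter) and an 11-fold higher number from compound 1 to compound 4 (1.04 log units; beyond the scatter); by their numbers, the three compounds run fluoro, then bromo, then methyl, with every step beyond the scatter. No measurement given here offers an explanation for any of these steps.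

Bromo and hydrogen form the only pair compared at this position, and that pair has bromo on the other ring, so it remains open whether the same step would appear with fluoro or methyl there. On these data alone, it also remains open whether a methoxy group, an amine or a carboxylic acid at this position would give a number nearer that of compound 3 or that of compound 4.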